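From Methyl Ester to Dimethylamide in CDK8 Inhibitors

A few compounds are considered here, and "the series" means these few. Any claim that something is new, unique, unknown or untested is made for them only; others in the source may bear on it.

Within the data shown here, compound 2 `COC(=O)/C=C/c1ccncc1-c1ccc2ccccc2c1` gives 40.6 nM in an assay on a protein complex for inhibition of CDK8/Cyclin C (Homo sapiens), with a stated time of 1 h (a higher number here means a weaker inhibitor, a lower number a stronger inhibitor), the higher of the two numbers measured so far; compound 1 `Cn1ccc2cc(-c3cnccc3/C=C/C(=O)O)ccc21` gives 26.8 nM in this assay, a gap within the usual scatter, so the two cannot be ordered. Compound 3 `CN(C)C(=O)/C=C/c1ccncc1-c1ccc2ccccc2c1` differs from compound 2 in a single place: dimethylamino in place of methoxy on a carbonyl carbon. Among the measured compounds shown here, no measured pair isolates this change, so the step must be judged from the structures alone. No shift beyond the scatter is expected, and the step is estimated at a 1.2-fold lower number from compound 2 to compound 3 (0.06 log units; within the scatter). Compound 3 is therefore expected to give 35 nM in this assay, within a range from 10 nM to 120 nM.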

Compound 3, half-maximal inhibitory concentration: 30.1 nM
For compound 3 the middle estimate is 1.2-fold (0.07 log units) above the measured one; the range from low to high includes it.
By their numbers in this assay, from the lowest: compounds 1, 3 and 2 (each within the scatter of the next).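

Among these compounds, the step of a 1.3-fold lower number from compound 2 to compound 3 (0.13 log units; within the scatter) in this assay is the first measured pair to isolate a change on this carbonyl carbon. It shows that, on the core of compound 2, the dimethylamino of the amide can take the place of the methoxy of the ester with no shift that stands out from the scatter. Nothing measured here offers an explanation for this result. Still open, from the compounds shown here alone, is how a morpholine or a simple amino group on this carbonyl carbon would read, and whether a longer chain would hold up as well.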